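The source may hold more compounds than are shown below. What is called first, only, known or untested is meant among the compounds shown, and "the series" means these compounds.

Compound 1, `O=[N+]([O-])c1cccc(CNc2cc(C(F)(F)F)cc3[nH]ncc23)c1`, was tested in an assay for inhibition of Indoleamine 2,3-dioxygenase 1 (Homo sapiens), with stated times of 10 min and 60 min; a lower number here means a stronger inhibitor, a higher number a weaker inhibitor. There compound 1 gives only a limit of the assay, > 100000 nM, so no number is known for it. Compound 2, `CC(C)n1ncc2c(NCc3ccccc3[N+](=O)[O-])cc(C(F)(F)F)cc21`, likewise gives only a limit in this assay, > 100000 nM. Compound 1 therefore stands at the edge of what the assay can report, and so does its one companion, since the limit of > 100000 nM in this assay, at which 2 of the 2 values shown sit, shows that every value here is such a limit. The next compound, compound 3, `Nc1cccc(CNc2cc(C(F)(F)F)cc3[nH]ncc23)c1`, differs from compound 1 in one place: amino in place of nitro on an aromatic carbon. For the measured compounds named here, no step between two measured compounds is available, so nothing measured speaks for a change in either direction. With both measured compounds at the limit, the expected step of an at least 1.1-fold lower number from compound 1 to compound 3 (0.04 log units; that floor lies within the scatter) is none beyond the scatter, with a modest gain left open. Compound 3 is expected to give 90000 nM, within a range from 20000 nM to 300000 nM, most likely again as a limit.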

Compound 3, half-maximal inhibitory concentration: > 100000 nM
Compound 3 was reported as a limit; the forecaster's own chance of this, stated with the estimate: 65%; middle value at least 1.1-fold (0.04 log units) from the limit.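

Compound 1 and compound 3 both give only a limit in this assay, so the swap of nitro for amino yields no readable step: the limit of > 100000 nM in this assay, at which 3 of the 3 values shown sit.

The compounds shown leave open how strongly any of them inhibits, and whether nitro or amino is the better group at this place.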